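A few compounds are considered here, and "the series" means these few. Any claim that something is new, unique, unknown or untested is made for them only; others in the source may bear on it.

In a functional assay on HL-60 cells (Homo sapiens), with a stated time of 2 days (on this read-out lower numbers stand for stronger inhibition and higher numbers for weaker inhibition), compound 1 `O=C(NCc1ccccc1)c1nc[nH]c1C(=O)Nc1ccc(Cl)c(Cl)c1` gives 11500 nM and compound 2 `C[C@@H](NC(=O)c1[nH]cnc1C(=O)Nc1ccc(Cl)c(Cl)c1)c1ccccc1` gives 8800 nM. These two values lie within the usual scatter of each other, so compound 2 stands level with compound 1, and both show only weak inhibition on this read-out. Compound 3 `COC(=O)[C@@H](NC(=O)c1[nH]cnc1C(=O)Nc1ccc(Cl)c(Cl)c1)C(C)C` keeps the shared core of compound 2 and carries 1-(methoxycarbonyl)-2-methylpropyl in place of 1-phenylethyl on an amide-type nitrogen. For the measured compounds named here, the entering group has no ring, and no measured pair shows what losing the six-membered aromatic ring does. The expectation therefore rests on compound 2 at 8800 nM alone and is loose. Only a small shift towards weaker inhibition, not clearly beyond the scatter, is expected: a 1.6-fold higher number from compound 2 to compound 3 (0.20 log units; within the scatter). For compound 3 the estimated value is 14000 nM, with an expected range of 5000 nM to 40000 nM.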

Compound 3, half-maximal inhibitory concentration: > 62500 nM
Compound 3 was reported as a limit (the forecaster's own chance of this, stated with the estimate: 20%); middle value at least 4.4-fold (0.64 log units) from the limit.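

In this assay compound 3 gives > 62500 nM, which is a limit of the assay and not a number. Even so, placing 1-(methoxycarbonyl)-2-methylpropyl in place of 1-phenylethyl on the amide-type nitrogen gives an at least 7.1-fold higher number from compound 2 to compound 3 (0.85 log units; beyond the scatter), which shows that this position does not tolerate every group of the same heavy-atom count, something the earlier compounds, both with a six-membered aromatic ring here and within the scatter of each other, could not show. Only the smallest possible size of this step is known, and the result rests on a single limit: the limit of > 62500 nM in this assay, at which 1 of the 3 values shown sits.

The change removes the ring and brings in the methyl ester together, so the compounds shown do not separate the two. A plain 2-methylpropyl chain without the ester, or a carboxylic acid in its place, would bear on that question.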